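The source may hold more compounds than are shown below. What is called first, only, known or untested is meant among the compounds shown, and "the series" means these compounds.

Measured in a functional assay (aorta) with Rattus norvegicus as the target; on this read-out lower numbers stand for stronger inhibition and higher numbers for weaker inhibition:
- compound 1 `CCCCN(CCCC)CCCOc1ccc(S(=O)(=O)c2c(CC)cn3ccccc23)cc1`: 31.3 nM
- compound 2 `CCCCCN(CCCCC)CCCOc1ccc(S(=O)(=O)c2c(CC)cn3ccccc23)cc1`: 62.4 nM

Compound 2 stands within the scatter of compound 1, so the two values are not separated. Compound 3 `CCc1cn2ccccc2c1S(=O)(=O)c1ccc(OCCCN2CCCCC2)cc1` is still unmeasured and departs from compound 2 as follows: piperidin-1-yl in place of dipentylamino on a saturated chain carbon, three bonds along the chain from an oxygen on an aromatic ring.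

Among the measured compounds shown here, one measured step bears on this change, at the same place on the chain: a 2.0-fold higher number from compound 1 to compound 2 (0.30 log units; within the scatter). For the measured compounds named here, no measured compound carries a ring there, so neither direction is supported. The expected size in this assay is a 1.2-fold lower number from compound 2 to compound 3 (0.10 log units; within the scatter), which means no expected change beyond the scatter.

For compound 3 the estimated value is 50 nM, with an expected range of 10 nM to 250 nM.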

Compound 3, half-maximal inhibitory concentration: 357 nM
Compound 3: middle estimate off by 7.1-fold (0.85 log units), on the low side; the measured number lies above the stated range.
By their numbers in this assay, from the lowest: compounds 1 and 2 (each within the scatter of the next); then compound 3.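

Piperidin-1-yl on this chain carbon gives a 5.7-fold higher number from compound 2 to compound 3 (0.76 log units; beyond the scatter) and an 11-fold higher number from compound 1 to compound 3 (1.06 log units; beyond the scatter) in this assay and so separates from both open-chain amines, which the dibutylamino to dipentylamino change had not shown. The read-out at this place therefore does respond to the amine group. No measured evidence accounts for this step.

Piperidin-1-yl differs from both open-chain groups in having a ring and in having fewer heavy atoms, so which of the two goes with the step remains open. Diethylamino at this place would separate the two.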